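Two demethylations on one cytotoxic series

This account rests on a few compounds, and the source may have more. Where it says the series, first, only, none or still open, it means among the compounds named here.

Measured so far, in a functional assay on cells (Fibrosarcoma cell line, Homo sapiens) for cytotoxicity; on this read-out higher numbers stand for an effect only at larger amounts of compound and lower numbers for an effect already at smaller amounts:
compound 1 `COC1=C(OC)[C@@]2(OC)c3c(OC)c(OC)c4c(c3O[C@@]23O[C@@H](c2ccccc2)CC=C3C1=O)[C@@H](OC)C[C@H](c1ccccc1)O4`: 0.4 ug/mL
compound 2 `COC1=C(OC)[C@@]2(OC)c3c(O)c(OC)c4c(c3O[C@@]23O[C@@H](c2ccccc2)CC=C3C1=O)[C@@H](OC)C[C@H](c1ccccc1)O4`: 1.8 ug/mL

Going by the values given here, compound 2 stands highest of the two numbers; the single measured step is a 4.5-fold higher number from compound 1 to compound 2 (0.65 log units; beyond the scatter). Compound 3 `COC1=C(OC)[C@@]2(OC)c3c(O)c(OC)c4c(c3O[C@@]23O[C@@H](c2ccccc2)CC=C3C1=O)[C@@H](O)C[C@H](c1ccccc1)O4` differs from compound 2 by hydrogen in place of methyl on an oxygen on a saturated carbon. Among the compounds with values here, no measured step touches this place; the step of a 4.5-fold higher number from compound 1 to compound 2 (0.65 log units; beyond the scatter) removes a methyl at an oxygen on an aromatic ring and so bears only loosely on this change. A small rise or no step beyond the scatter in this assay is therefore expected. For compound 3 the estimate is 3 ug/mL (range 1 ug/mL to 10 ug/mL), which is expected to amount to a 1.7-fold higher number from compound 2 to compound 3 (0.22 log units; within the scatter).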

Compound 3, half-maximal effective concentration: 0.8 ug/mL
Compound 3: the middle estimate sits 3.8-fold (0.57 log units) above what was measured, and the stated range ends above it.
By their numbers in this assay, from the lowest: compounds 1 and 3 (each within the scatter of the next); then compound 2.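

In this assay, methoxy to hydroxy on the saturated carbon gives a 2.3-fold lower number from compound 2 to compound 3 (0.35 log units; beyond the scatter) and so runs opposite in direction to the same loss of methyl on an oxygen on an aromatic ring. The two oxygens of this series therefore do not respond alike, and one site cannot stand in for the other. No measurement at hand accounts for this difference. Open, as far as these compounds go, is whether an acetate ester or an amine at this saturated carbon moves the number further. Also open, from the compounds shown here alone, is how the remaining methoxy groups of the shared core respond to the same change.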